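Anilide in place of the acid on the shared core

The source may report more compounds than this note shows. Statements on the series, on what has been measured and on what is new or still open speak of the compounds shown alone.

Compound 1 `CCCSc1nc(Cl)c2c(n1)N(Cc1ccccc1)C(C(=O)O)N2` is known in a functional assay on TE-1 cells (Homo sapiens) for antiproliferative activity, read by MTT assay, with a stated time of 72 h (on this read-out lower numbers stand for stronger inhibition and higher numbers for weaker inhibition), only by a limit, > 64000 nM. Compound 3 `CCCSc1nc(Cl)c2c(n1)N(Cc1ccccc1)C(C(=O)OCC)N2` likewise gives only a limit in this assay, > 64000 nM. Compound 2 `CCCSc1nc(Cl)c2c(n1)N(CC1CCCCC1)C(C(=O)N1CCN(C)CC1)N2` also sits at a limit in this assay, > 64000 nM. Within the data shown here, the one single-point step, a step that the two limits leave unreadable from compound 1 to compound 3, is therefore unreadable, and the whole picture so far is the limit of > 64000 nM in this assay, at which 3 of the 3 values shown sit. Compound 4 `CCCSc1nc(Cl)c2c(n1)N(Cc1ccccc1)C(C(=O)Nc1ccccc1)N2` differs from compound 1 by anilino in place of hydroxy on a carbonyl carbon. Among the measured compounds shown here, no measured step bears on this change with a readable size, so there is no ground to expect a move beyond the scatter in either direction. Compound 4 is therefore expected to remain near the limit, estimated at 70000 nM, within 15000 nM to 300000 nM. The expected step is a step that the limit leaves unreadable from compound 1 to compound 4.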

Compound 4, half-maximal inhibitory concentration: > 64000 nM
Compound 4: only a limit was reported; the forecaster's own chance of this, stated with the estimate: 80%; the middle value lies beyond the limit too.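

The steps from compound 1 and from compound 3 to compound 4 cannot be read, since all three compounds give only limits: the limit of > 64000 nM in this assay, at which 4 of the 4 values shown sit. Going by these compounds, it remains open whether any change gives a measurable value in this assay on the shared core.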